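The source may report more compounds than this note shows. Statements on the series, on what has been measured and on what is new or still open speak of the compounds shown alone.

Compound 2 `O=C([C@H](O)c1ccccc1)N1CCN(c2ccc3[nH]ncc3c2)CC1` gives 800 nM in an assay on isolated protein for inhibition of Rho-associated protein kinase 2 (Homo sapiens); on this read-out higher numbers stand for weaker inhibition and lower numbers for stronger inhibition. Going by the values given here, compound 1 `CC(C)[C@@H](O)C(=O)N1CCN(c2ccc3[nH]ncc3c2)CC1` gives 3900 nM, and the only measured step here, a 4.9-fold lower number from compound 1 to compound 2 (0.69 log units; beyond the scatter), alters a different part of the molecule. Compound 3 `NC(C(=O)N1CCN(c2ccc3[nH]ncc3c2)CC1)c1cccc(Cl)c1` gives 760 nM, a number within the scatter of compound 2, although the two differ in two places, one of them being an amino group on a saturated chain carbon bound to an aromatic carbon and a carbonyl carbon. Compound 4 `N[C@@H](C(=O)N1CCN(c2ccc3[nH]ncc3c2)CC1)c1ccccc1` is the unmeasured result of the change (amino in place of hydroxy on a saturated chain carbon bound to an aromatic carbon and a carbonyl carbon). Because compound 3 gives 760 nM with that amino group present, the expected outcome is a 1.1-fold lower number from compound 2 to compound 4 (0.06 log units; within the scatter), nothing beyond the scatter. Compound 4 is therefore estimated at 700 nM, within 300 nM to 1600 nM.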

Compound 4, half-maximal inhibitory concentration: 1300 nM
Compound 4: the middle estimate sits 1.9-fold (0.27 log units) below what was measured, and the stated range covers the measured number.
By their numbers in this assay, from the lowest: compounds 3, 2 and 4 (each within the scatter of the next); then compound 1.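

On the saturated chain carbon bound to an aromatic carbon and a carbonyl carbon, amino in place of hydroxy gives a 1.6-fold higher number from compound 2 to compound 4 (0.21 log units; within the scatter) in this assay, so with phenyl present this assay does not separate the two groups. Amino(phenyl)methyl in place of 1-hydroxy-2-methylpropyl gives a 3.0-fold lower number from compound 1 to compound 4 (0.48 log units; beyond the scatter), so the lower number relative to compound 1 remains with amino at this carbon. Nothing available explains these results. Still open, from the compounds shown here alone, is how a methoxy group or a dimethylamino group on this carbon would read, or a plain hydrogen there.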